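Hexylamino for sulfanyl on a nucleoside core

The source may hold more compounds than are shown below. What is called first, only, known or untested is meant among the compounds shown, and "the series" means these compounds.

Measured compounds:
compound 1, `CCCCCCNc1[nH]ccc2ncnc1-2`: 100%
compound 2, `[N-]=[N+]=Nc1nccc2ncn([C@H]3C[C@H](O)[C@@H](CO)O3)c12`: < 5%
compound 3, `OC[C@H]1OC(n2cnc3c(S)nccc32)[C@H](O)[C@@H]1O`: < 5%

In a functional assay on EL4 cells (Mus musculus) for inhibition, tested at 100 uM (on this read-out higher numbers stand for more inhibition at the one concentration tested (going by the name of the read-out) and lower numbers for less inhibition), compound 1 reaches 100%. For compound 2 only a limit is reported, < 5%. Compound 3 likewise sits at a limit, < 5%, which is the limit of < 5% in this assay, at which 2 of the 3 values shown sit. Compound 3 therefore stands at the bottom of what has been seen so far.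

Compound 4, `CCCCCCNc1nccc2c1ncn2C1O[C@H](CO)[C@@H](O)[C@H]1O`, is not yet measured. It differs from compound 3 by hexylamino in place of sulfanyl on an aromatic carbon. Among the compounds with values here, the hexylamino group is the one found on compound 1, which gives 100% in this assay. The sugar-bearing compound 2 and compound 3, by contrast, both sit at the limit already described. An upward step from compound 3 is expected, a number at least 35 percentage points higher from compound 3 to compound 4 (beyond the scatter), beyond the scatter. For compound 4 an inhibition of 40% is estimated, between 5% and 90%.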

Compound 4, a percentage reported as inhibition, at one concentration (the size of the read-out at that concentration, not a potency): 14%
Beside the measured number, compound 4's estimate is 26 percentage points above it; measured number inside the range.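

On an aromatic carbon of the shared core, hexylamino in place of sulfanyl gives a number at least 9 percentage points higher from compound 3 to compound 4 (that floor lies within the scatter) in this assay. Compound 4 thus has a measured number, yet the change is not shown to reach beyond the scatter. The step can be read only as a floor because compound 3 sits at a limit and not at a number: the limit of < 5% in this assay, at which 2 of the 4 values shown sit.

Going by these compounds, whether a shorter chain such as butylamino, a longer chain such as octylamino, or a carboxylic acid at this place would read differently in this assay stays open.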